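Benzylamino in place of methoxy on a carbonyl carbon

The compounds below may be only part of what the source reports. "The series", "measured", "known", "first", "only" and "open" are said of these compounds alone.

Compound 2 `COC(=O)c1nc(Br)c2cccnc2c1N[C@H]1CC[C@H](N)CC1` offers no number to start from. In a functional assay on MDA-MB-435 cells (Homo sapiens) for cytotoxicity, read by MTT assay, with a stated time of 72 h (on this read-out lower numbers stand for stronger inhibition and higher numbers for weaker inhibition), compound 2 gives > 20000 nM, which is a limit of the assay. Going by the values given here, compound 1 `C[C@H](NC(=O)c1nc(Br)c2cccnc2c1N[C@H]1CC[C@H](N)CC1)c1ccc(F)cc1` is the only other compound measured. In this assay compound 1 gives > 10000 nM, and this too is a limit.

Compound 3 `N[C@H]1CC[C@H](Nc2c(C(=O)NCc3ccccc3)nc(Br)c3cccnc23)CC1` differs from compound 2 in one place: benzylamino in place of methoxy on a carbonyl carbon. Benzylamino replaces methoxy on a carbonyl carbon, so compound 3 is an amide like compound 1, although with a different amino group.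

Among the compounds with values here, only one measured step bears on this change: a step that the two limits leave unreadable from compound 1 to compound 2. It swaps methoxy for a related amino group on a carbonyl carbon, but its size cannot be read. It therefore gives no sign of a real gain or loss when methoxy is replaced. Compound 3 is expected to stay in the same weak range as these two compounds, and a reported limit is the likeliest outcome. The estimated step is an at least 1.3-fold lower number from compound 2 to compound 3 (0.12 log units; that floor lies within the scatter), with no change beyond the usual scatter expected. For compound 3 the estimated value is 15000 nM, with an expected range of 4000 nM to 40000 nM.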

Compound 3, half-maximal inhibitory concentration: 7000 nM
Compound 3: the middle estimate sits 2.1-fold (0.33 log units) above what was measured, within the range that was stated.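

Going by these compounds alone, compound 3 gives the first value in this assay that is not a limit, and it shows that this place on the carbonyl carbon can register a change: benzylamino in place of methoxy gives an at least 2.8-fold lower number from compound 2 to compound 3 (0.45 log units; beyond the scatter). The comparison of the two amides, with benzyl in place of 1-(4-fluorophenyl)ethyl on an amide-type nitrogen, gives an at least 1.4-fold lower number from compound 1 to compound 3 (0.15 log units; that floor lies within the scatter), so these two groups cannot be told apart on the values shown. That comparison starts from a limit of the assay for compound 1: the limit of > 10000 nM in this assay, at which 1 of the 3 values shown sits.

On these data alone, the true size of the gain from methoxy to benzylamino remains open, as compound 2 also has only a limit of the assay: the limit of > 20000 nM in this assay, at which 1 of the 3 values shown sits. Also open is whether a plain amine or a carboxylic acid in place of benzylamino on the carbonyl carbon, or a longer chain joining the amide nitrogen to the phenyl ring, would shift the read-out further from the value of compound 3.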